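Urea-linked pyrazoles: a trifluoromethyl for dichloro swap

This account rests on a few compounds, and the source may have more. Where it says the series, first, only, none or still open, it means among the compounds named here.

Measured compounds:
- compound 1, `COc1cc(Cl)cc(-c2nn(-c3cccc(NC(=O)Nc4ccc(Cl)c(C(F)(F)F)c4)c3)cc2-c2ccncc2)c1`: 43%
- compound 2, `COc1cc(Cl)cc(-c2nn(-c3cccc(NC(=O)Nc4cc(C(F)(F)F)cc(C(F)(F)F)c4)c3)cc2-c2ccncc2)c1`: 13%
- compound 3, `COc1cc(Cl)cc(-c2nn(-c3cccc(NC(=O)Nc4ccc(Cl)c(Cl)c4)c3)cc2-c2ccncc2)c1`: 77%

In a functional assay on NCI-H460 cells (Homo sapiens) for inhibition, read by sulforhodamine B assay, with a stated time of 48 h, tested at 1 uM (on this read-out lower numbers stand for a stronger effect and higher numbers for a weaker effect at the one concentration tested), compound 3 gives the highest number of the three, so the weakest effect; compound 1 sits below it and compound 2 lowest of all. Within the data shown here, the one single-point step among the measured compounds, a number 34 percentage points higher from compound 1 to compound 3 (beyond the scatter), is large and runs toward a weaker effect. Compound 4, `COc1cc(Cl)cc(-c2nn(-c3cccc(NC(=O)Nc4cccc(C(F)(F)F)c4)c3)cc2-c2ccncc2)c1`, carries 3-(trifluoromethyl)phenyl in place of 3,4-dichlorophenyl on an amide-type nitrogen. That step moves back toward the trifluoromethyl-bearing side from which compound 1 and compound 2 came, so a lower number than compound 3 is expected. Compound 4 is therefore estimated at 45% (range 20% to 70%), a step of a number 32 percentage points lower from compound 3 to compound 4 (beyond the scatter) expected beyond the scatter.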

Compound 4, a percentage reported as activity, at one concentration (the size of the read-out at that concentration, not a potency): 45%
Compound 4: the middle estimate sits on the measured number at the digits printed; measured number inside the range.
By their numbers in this assay, from the lowest: compound 2; then compounds 1 and 4 (each within the scatter of the next); then compound 3.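

In this assay, hydrogen in place of chloro on an aromatic carbon gives a number 2 percentage points higher from compound 1 to compound 4 (within the scatter), so this chloro makes no reading difference here, while hydrogen in place of trifluoromethyl gives a number 32 percentage points higher from compound 2 to compound 4 (beyond the scatter). The change from 3,4-dichlorophenyl to 3-(trifluoromethyl)phenyl on the amide-type nitrogen gives a number 32 percentage points lower from compound 3 to compound 4 (beyond the scatter), which shows that a lone trifluoromethyl, with no chloro, is enough for this large step. Nothing given here explains these steps. From the compounds shown here alone, whether a nitrile or a carboxylic acid in place of that trifluoromethyl would hold the number remains open.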